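The source may hold more compounds than are shown below. What is called first, only, known or untested is meant among the compounds shown, and "the series" means these compounds.

Measured compounds and their numbers:

Compound 1, `CC(=O)OC[C@H]1O[C@H](OC[C@@H](Cn2cc(CN(c3nc(-c4cccc([N+](=O)[O-])c4)no3)C3CCCCC3)nn2)OC(C)=O)C=C[C@@H]1OC(C)=O`: in an ADME assay on RAW264.7 cells (Mus musculus) for cytotoxicity, read by MTT assay, with a stated time of 48 h (on this read-out higher numbers stand for lower toxicity in this test and lower numbers for higher toxicity in this test), compound 1 gives 100 ug/mL.
Compound 2, `CC(=O)OC[C@H]1O[C@H](OC[C@@H](Cn2cc(CN(c3nc(-c4ccc(C)cc4)no3)C3CCCCC3)nn2)OC(C)=O)C=C[C@@H]1OC(C)=O`: in this assay compound 2 gives 45.3 ug/mL.

Going by the values given here, compound 2 stands at the lower of the two numbers, meaning it was the more toxic of the pair in this assay; its only neighbour is compound 1, separated by the step of a 2.2-fold lower number from compound 1 to compound 2 (0.34 log units; beyond the scatter), which lies beyond the scatter.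

Compound 3, `CC(=O)OC[C@H]1O[C@H](OC[C@@H](Cn2cc(CN(c3nc(-c4ccccc4)no3)C3CCCCC3)nn2)OC(C)=O)C=C[C@@H]1OC(C)=O`, differs from compound 2 in one place: hydrogen in place of methyl on an aromatic carbon.

Among the compounds with values here, only one measured step exists, and it concerns a different change, the 3-nitrophenyl to 4-methylphenyl swap on the same aromatic ring, so it bears on the present step only loosely. That step was modest in size. The change from compound 2 to compound 3 is smaller, the loss of a single carbon. The expectation is therefore a small step, if any, in this assay, a 1.2-fold higher number from compound 2 to compound 3 (0.08 log units; within the scatter), likely within the scatter and, if anything, towards a higher number. For compound 3 the estimated value in this assay is 55 ug/mL, with a range from 25 ug/mL to 120 ug/mL.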

Compound 3, half-maximal cytotoxic concentration: 28.6 ug/mL
Beside the measured number, compound 3's estimate is 1.9-fold (0.28 log units) above it, and the stated range covers the measured number.
By their numbers in this assay, from the lowest: compounds 3 and 2 (each within the scatter of the next); then compound 1.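

In this assay, removing the methyl that sits para to a large group gives a 1.6-fold lower number from compound 2 to compound 3 (0.20 log units; within the scatter), which is within the scatter, so methyl and hydrogen cannot be told apart at this place on the ring. Compound 3 also provides the plain phenyl reference that the earlier pair lacked, and replacing the nitro group of compound 1 with hydrogen gives a 3.5-fold lower number from compound 1 to compound 3 (0.54 log units; beyond the scatter), which is beyond the scatter and leaves compound 1 clearly apart from both other compounds, with the highest number of the three. Nothing available here explains why the nitro compound stands apart in this test.

From the compounds shown here alone, it remains open whether other groups on this ring, such as an amine, a chlorine or a methoxy group, would give numbers like that of compound 1 or like those of compound 2 and compound 3. The names 3-nitrophenyl and 4-methylphenyl also show that the two groups occupy different places on the ring, so the compounds shown do not separate the influence of the group itself from that of its place.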